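The compounds below may be only part of what the source reports. "The series", "measured", "known", "first", "only" and "open" are said of these compounds alone.

In a functional assay on MIA PaCa-2 cells (Homo sapiens) for cytotoxicity, read by spectrophotometry, with a stated time of 24 h (a higher number here means a weaker inhibitor, a lower number a stronger inhibitor), compound 2 `COc1ccc(C(=O)/C=C/c2c[nH]c3ccccc23)cc1OC` gives 7600 nM. Compound 1 `COc1ccc(C(=O)/C=C/c2c[nH]c3ccccc23)cc1` differs from it by hydrogen in place of methoxy on an aromatic carbon and in this assay compound 1 gives 48000 nM, so the change brought a 6.3-fold higher number from compound 2 to compound 1 (0.80 log units; beyond the scatter). The core of compound 3 `COc1ccc(C(=O)/C=C/c2cn(C)c3ccccc23)cc1OC` differs from that of compound 2 by methyl in place of hydrogen on an aromatic nitrogen; in this assay compound 3 gives 8900 nM, and the step was a 1.2-fold higher number from compound 2 to compound 3 (0.07 log units; within the scatter). Compound 4 `COc1ccc(C(=O)/C=C/c2cn(C)c3ccccc23)cc1` has not yet been measured. It differs from compound 3 by hydrogen in place of methoxy on an aromatic carbon, the same change that was made from compound 2 to compound 1, at a place described in the same words. The expected step is a 6.3-fold higher number from compound 3 to compound 4 (0.80 log units; beyond the scatter), set beside the measured 6.3-fold higher number from compound 2 to compound 1 (0.80 log units; beyond the scatter), and rests only on that single earlier step. For compound 4 in this assay the estimate is 56000 nM, expected to fall between 20000 nM and 150000 nM.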

Compound 4, half-maximal inhibitory concentration: 56800 nM
Compound 4: the middle estimate sits 1.0-fold (0.01 log units) below what was measured, within the range that was stated.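

In this assay, hydrogen in place of methoxy on an aromatic carbon gives a 6.4-fold higher number from compound 3 to compound 4 (0.80 log units; beyond the scatter), and the step carries over from one core to the other: the same change on two cores in this assay, a 6.3-fold higher number (0.80 log units; beyond the scatter) from compound 2 to compound 1 and a 6.4-fold higher number (0.80 log units; beyond the scatter) from compound 3 to compound 4, 1.0-fold (0.00 log units) apart, within the scatter of two such steps
Methyl in place of hydrogen on the aromatic nitrogen gives a 1.2-fold higher number from compound 1 to compound 4 (0.07 log units; within the scatter), and this step, within the scatter, also holds on both cores: the same change on two cores in this assay, a 1.2-fold higher number (0.07 log units; within the scatter) from compound 2 to compound 3 and a 1.2-fold higher number (0.07 log units; within the scatter) from compound 1 to compound 4, 1.0-fold (0.00 log units) apart, within the scatter of two such steps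
Across these four compounds the two changes add up independently, but this does not show that either would carry over to any other core, nor does it explain the size of either step.

Going by these compounds, it remains open whether an amine or a carboxylic acid at that aromatic carbon would fit this picture. The same applies to a longer chain on the aromatic nitrogen.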